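A Chlorophenyl Piperazine Variant in the Sulfonamide Series

This account rests on a few compounds, and the source may have more. Where it says the series, first, only, none or still open, it means among the compounds named here.

Measured compounds:
compound 1 `CCCn1c(=O)[nH]c2nc(-c3ccc(S(=O)(=O)N4CCN(Cc5cccc(C)c5)CC4)cc3)[nH]c2c1=O`: 795 nM
compound 2 `CCCn1c(=O)[nH]c2nc(-c3ccc(S(=O)(=O)N4CCN(C)CC4)cc3)[nH]c2c1=O`: 334 nM
compound 3 `CCCn1c(=O)[nH]c2nc(-c3ccc(S(=O)(=O)N4CCN(c5cccc(Cl)c5)CC4)cc3)[nH]c2c1=O`: > 1000 nM

In an assay on CHO cells for displacement of a labelled ligand from adenosine receptor A1 (Homo sapiens), read by scintillation counting, with a stated time of 90 min, in the presence of a further agent that is not named here (on this read-out higher numbers stand for weaker inhibition and lower numbers for stronger inhibition), compound 1 gives 795 nM, the highest of the two numbers shown. Compound 2 gives 334 nM, and a 2.4-fold lower number from compound 1 to compound 2 (0.38 log units; beyond the scatter). Compound 3 gives > 1000 nM, which is a limit of this assay rather than a number (the limit of > 1000 nM in this assay, at which 1 of the 3 values shown sits).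

Compound 4 `CCCn1c(=O)[nH]c2nc(-c3ccc(S(=O)(=O)N4CCN(c5ccccc5Cl)CC4)cc3)[nH]c2c1=O` differs from compound 1 in one place: 2-chlorophenyl in place of 3-methylbenzyl on an amine nitrogen in a ring. For the measured compounds named here, two measured steps bear on this change, both placing an aromatic ring on the amine nitrogen in the ring: an at least 1.2-fold higher number from compound 1 to compound 3 (0.09 log units; that floor lies within the scatter), and an at least 2.9-fold higher number from compound 2 to compound 3 (0.47 log units; beyond the scatter). Both run toward weaker inhibition, and the second lies beyond the scatter, so a higher number is expected for compound 4 in this assay, with a fair chance that only a limit is reported. Compound 4 is therefore estimated at 1800 nM, within 700 nM to 5000 nM. This estimate means an expected step of a 2.3-fold higher number from compound 1 to compound 4 (0.35 log units; beyond the scatter).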

Compound 4, inhibition constant: > 1000 nM
Compound 4 gave a limit, no number; the forecaster's own chance of this, stated with the estimate: 60%; the middle value does not contradict the limit.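

In this assay compound 4 gives > 1000 nM, which is a limit and not a number, and a second chlorophenyl on the amine nitrogen in the ring now ends at this limit: the limit of > 1000 nM in this assay, at which 2 of the 4 values shown sit. With an at least 1.2-fold higher number from compound 1 to compound 4 (0.09 log units; that floor lies within the scatter) the comparison with 3-methylbenzyl stays unresolved, whereas an at least 2.9-fold higher number from compound 2 to compound 4 (0.47 log units; beyond the scatter) places 2-chlorophenyl, like 3-chlorophenyl, on the side of weaker inhibition relative to methyl. The step between the two chlorophenyl compounds cannot be read, since both values are limits, so nothing can be said of 2-chlorophenyl against 3-chlorophenyl.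

On these data alone, it remains open whether an unsubstituted phenyl or a methoxyphenyl on this nitrogen would give a readable number. As far as these compounds go, it is also open whether an ethyl group or a hydrogen there would give a lower number than compound 2 does.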